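Replacing 4-aminophenyl with 1-phenylethyl

The source may hold more compounds than are shown below. What is called first, only, known or untested is meant among the compounds shown, and "the series" means these compounds.

Measured in a functional assay on HCT-116 cells (Homo sapiens) for cytotoxicity, read by MTT assay, with a stated time of 72 h; a lower number here means a stronger inhibitor, a higher number a weaker inhibitor:
- compound 1 `CS(=O)(=O)Oc1c(C(=O)NCc2ccc(F)cc2)nc(Br)c2cccnc12`: > 20000 nM, a limit
- compound 2 `NCCCNc1c(C(=O)NCc2ccc(F)cc2)nc(Br)c2cccnc12`: > 20000 nM, a limit
- compound 3 `Nc1ccc(Nc2c(C(=O)NCc3ccc(F)cc3)nc(Br)c3cccnc23)cc1`: 10000 nM

In this assay, within the data shown here, compound 3 holds the only true number of the three, at 10000 nM. The other two results are limits, and the evidence on them is the limit of > 20000 nM in this assay, at which 2 of the 3 values shown sit. Compound 4 `C[C@H](Nc1c(C(=O)NCc2ccc(F)cc2)nc(Br)c2cccnc12)c1ccccc1` differs from compound 3 by one change, 1-phenylethyl in place of 4-aminophenyl on a nitrogen on an aromatic ring.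

The nearest guide is an at least 2.0-fold lower number from compound 2 to compound 3 (0.30 log units; that floor lies within the scatter), which also exchanges the group on that nitrogen. A second measured step, an at least 2.0-fold lower number from compound 1 to compound 3 (0.30 log units; that floor lies within the scatter), changes a different linking atom and says less. Neither step shows a change beyond the scatter, so neither supports a large expected shift. A small move toward a higher number is expected, as the amino group of the 4-aminophenyl leaves.

The expected step is a 1.6-fold higher number from compound 3 to compound 4 (0.20 log units; within the scatter), which stays within the scatter. For compound 4 the estimated value is 16000 nM, with an expected range of 7000 nM to 35000 nM.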

Compound 4, half-maximal inhibitory concentration: > 20000 nM
Compound 4 was reported as a limit; the forecaster's own chance of this, stated with the estimate: 45%; middle value at least 1.2-fold (0.09 log units) from the limit.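

With an at least 2.0-fold higher number from compound 3 to compound 4 (0.30 log units; that floor lies within the scatter), the result shows that a six-membered aromatic ring of carbon on this nitrogen does not by itself give a true number: 1-phenylethyl carries such a ring, as 4-aminophenyl does, yet compound 4 is reported only as a limit. The steps to compound 4 from compound 1 and from compound 2 cannot be read, as both ends of each are limits. Compound 3 remains the only one of the four with a true number in this assay, and compound 4 joins the others at the limit: the limit of > 20000 nM in this assay, at which 3 of the 4 values shown sit.

This single change both removes the amino group and replaces 4-aminophenyl with a different carbon framework, so the compounds shown cannot separate those two differences. Plain phenyl or benzyl on that nitrogen would bear on this, and the opposite stereoisomer of 1-phenylethyl also remains open.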